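Chloro replacing 1-(trifluoromethyl)cyclopropyl on the aryl ring

The source may hold more compounds than are shown below. What is called first, only, known or untested is meant among the compounds shown, and "the series" means these compounds.

Compound 1 `Cn1nc(CN2CCCC2)nc1-c1ccc(C2(C(F)(F)F)CC2)cc1` carries the shared core with a 1-(trifluoromethyl)cyclopropyl group on a six-membered aromatic ring of carbon only. In an assay on membranes from Jurkat cells for displacement of a labelled ligand from Sigma intracellular receptor 2 (Homo sapiens), read by scintillation counting, with a stated time of 1 h (a higher number here means a weaker inhibitor, a lower number a stronger inhibitor), compound 1 reaches only a limit, > 1000 nM, so its standing among the measured values is not a number but (the limit of > 1000 nM in this assay, at which 2 of the 3 values shown sit). Compound 2 `Cn1nc(CN2CCCC2)nc1-c1cccc(C(C)(C)C)c1` gives 1000 nM in this assay. Compound 3 `Cn1nc(CN2CCCC2)nc1-c1ccc2c(c1)CCCC2` also gives only a limit in this assay, > 1000 nM. Compound 4 `Cn1nc(CN2CCCC2)nc1-c1ccc(Cl)cc1` differs from compound 1 by chloro in place of 1-(trifluoromethyl)cyclopropyl on an aromatic carbon. For the measured compounds named here, no measured pair isolates this change, so its size is not known from the data. The expected step in this assay is an at least 1.6-fold lower number from compound 1 to compound 4 (0.22 log units; that floor lies within the scatter), modest and if anything toward stronger binding, possibly not beyond the scatter. Compound 4 is estimated at 600 nM, within 150 nM to 3000 nM.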

Compound 4, inhibition constant: > 1000 nM
Compound 4 gave a limit, no number; the forecaster's own chance of this, stated with the estimate: 35%; middle value at least 1.6-fold (0.22 log units) from the limit.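

Compound 1 and compound 4 both end at a limit in this assay, so no step between them can be read: the limit of > 1000 nM in this assay, at which 3 of the 4 values shown sit.

On these data alone, how far chloro in place of 1-(trifluoromethyl)cyclopropyl shifts binding remains open, as does any order among the compounds held at that limit.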